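Trifluoromethyl in place of hydrogen on the aromatic oxygen

The source may report more compounds than this note shows. Statements on the series, on what has been measured and on what is new or still open speak of the compounds shown alone.

Compound 2 `CC(C)N(Cc1cccc(OCCCCCC(=O)O)c1)C(=O)c1ccc(-c2cccc(O)c2)cc1` is the reference point for this step. In an ADME assay on Raji cells (Homo sapiens) for cytotoxicity, read by CellTiter-Glo and resazurin assay, with a stated time of 72 h (on this read-out lower numbers stand for an effect already at smaller amounts and higher numbers for an effect only at larger amounts of compound), compound 2 gives > 26000 nM, which is a limit of the assay and not a number. Compound 1 `CCOc1cccc(-c2ccc(C(=O)N(Cc3cccc(OCCCCCC(=O)O)c3)C(C)C)cc2)c1` carries ethyl on the same oxygen; in this assay compound 1 gives > 20800 nM, again a limit. The step that the two limits leave unreadable from compound 1 to compound 2 cannot be sized because the limit of > 20800 nM in this assay, at which 1 of the 2 values shown sits, and the limit of > 26000 nM in this assay, at which 1 of the 2 values shown sits, place both ends at limits. Compound 3 `CC(C)N(Cc1cccc(OCCCCCC(=O)O)c1)C(=O)c1ccc(-c2cccc(OC(F)(F)F)c2)cc1` is the unmeasured member of the series: trifluoromethyl in place of hydrogen on an oxygen on an aromatic ring. Among the measured compounds shown here, the only measured step on this oxygen, ethyl to hydrogen, gives no readable size, so no direction beyond the scatter is expected for the change from compound 2 to compound 3. Both measured compounds sit at limits in this assay. Compound 3 is expected to do the same, with an estimated step that the limit leaves unreadable from compound 2 to compound 3. The estimate for compound 3 in this assay is 30000 nM, with a range from 8000 nM to 100000 nM, most likely reported only as a limit.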

Compound 3, half-maximal effective concentration: > 26000 nM
Compound 3: a limit, no number (the forecaster's own chance of this, stated with the estimate: 75%); the middle value lies beyond the limit too.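

Compound 3 gives only a limit in this assay, as do compound 1 and compound 2, so no step among these three compounds can be read: the limit of > 26000 nM in this assay, at which 2 of the 3 values shown sit.

The compounds shown leave open whether the group on the aromatic oxygen affects the read-out in this assay at all, and at what concentration any of the three would reach a half-maximal effect.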